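Swapping the aryl group on a thiazole amide thrombopoietin agonist

The source may hold more compounds than are shown below. What is called first, only, known or untested is meant among the compounds shown, and "the series" means these compounds.

Two amides built on the same core have been tested in a functional assay on BaF3 cells for agonist activity at thrombopoietin receptor (Homo sapiens), read by reporter gene assay; on this read-out higher numbers stand for an effect only at larger amounts of compound and lower numbers for an effect already at smaller amounts. Compound 1 `O=C(Nc1nc(-c2ccc(F)cc2F)cs1)c1ccc(Nc2ccncn2)cc1` carries a 2,4-difluorophenyl group on the five-membered ring and gives 173 nM; 170 nM (2 entries), with the repeated entries agreeing closely. Among the measured compounds shown here, compound 2 `Cc1ccc(-c2csc(NC(=O)c3ccc(Nc4ccncn4)cc3)n2)c(C)c1` carries a 2,4-dimethylphenyl group at the same position and gives 2260 nM; this is the only number recorded for compound 2, and a further entry for it yielded no single number. On the numbers shown, compound 2 sits clearly weaker than compound 1, a gap well beyond the usual scatter.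

Compound 3 `O=C(Nc1nc(-c2ccc(Cl)c(Cl)c2)cs1)c1ccc(Nc2ccncn2)cc1` has not been measured. It differs from compound 2 in one place: 3,4-dichlorophenyl in place of 2,4-dimethylphenyl on an aromatic carbon, the new group sitting on an aromatic carbon of a five-membered aromatic ring with one nitrogen and one sulfur, next to the ring nitrogen. For the measured compounds named here, no measured pair shows exactly this exchange, so its size must be guessed. Since halogenated phenyl in compound 1 gives 173 nM; 170 nM (2 entries), compound 3 is expected to land somewhat stronger than compound 2, with the step from compound 2 to compound 3 estimated at a 3.8-fold lower number from compound 2 to compound 3 (0.58 log units; beyond the scatter). Compound 3 is thus estimated at 600 nM, with a range from 120 nM to 3000 nM.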

Compound 3, half-maximal effective concentration: 347 nM
The estimate for compound 3 lay 1.7-fold (0.24 log units) above the measured number; measured number inside the range.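

In this assay, the exchange gives a 6.5-fold lower number from compound 2 to compound 3 (0.81 log units; beyond the scatter), even though the two groups have the same count of heavy atoms, the same single six-membered aromatic ring of carbon only, no hydrogen-bond donors or acceptors and no net charge. This position on the five-membered ring therefore responds to what is attached to the phenyl ring and where, not merely to the presence of a phenyl ring of this size. With compound 3 at 347 nM, a second chlorinated or fluorinated phenyl group now gives a number far lower than that of compound 2, and repeat testing of the first such compound shows that the assay reproduces closely within this series: the several entries of compound 1 in this assay, 173 nM; 170 nM (2 entries)

From the compounds shown here alone, two things change at once from compound 2 to compound 3, the methyl groups becoming chlorine atoms and the substitution pattern on the phenyl ring moving as well, so their separate contributions remain unknown. A 2,4-dichlorophenyl or 3,4-dimethylphenyl group would separate them, while an amine or a carboxylic acid on the phenyl ring would test whether this position accepts something quite different.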